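A few compounds are considered here, and "the series" means these few. Any claim that something is new, unique, unknown or untested is made for them only; others in the source may bear on it.

Notes on the series: in a physicochemical assay for lipophilicity, at pH 7.4 (on this read-out lower numbers stand for lower lipophilicity and higher numbers for higher lipophilicity), compound 1 `COC(c1cc(Cl)c2c(c1Cl)C(=O)N(Cc1c(C)cc(C)[nH]c1=O)CC2)C1CCS(=O)(=O)CC1` gives 2.2; 2.2 (2 entries), compound 2 `Cc1cc(C)c(CN2CCc3c(Cl)cc([C@H](CO)[C@@H]4CCCO4)c(Cl)c3C2=O)c(=O)[nH]1` gives 2.4 and compound 3 `Cc1cc(C)c(CN2CCc3c(Cl)cc([C@@H](CO)[C@@H]4CCOC4)c(Cl)c3C2=O)c(=O)[nH]1` gives 2. Compound 3 sits clearly under compound 2, while the value of compound 1 lies within the scatter of both.

Compound 4 `Cc1cc(C)c(CN2CCc3c(Cl)cc([C@H](C)CO)c(Cl)c3C2=O)c(=O)[nH]1` has not been measured yet. Its difference from compound 3 is methyl in place of oxolan-3-yl on a saturated chain carbon bound to an aromatic carbon and a saturated chain carbon.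

Among the measured compounds shown here, only one measured step bears on this change, and only loosely: a number 0.40 log units lower from compound 2 to compound 3 (beyond the scatter). For the measured compounds named here, that step exchanges one ring-bearing group for another of equal heavy-atom count, so no measured pair shows the loss of the ring. It serves only as a guide to how large a change at this carbon can be, and the direction stays uncertain.

The expected shift in this assay is a number 0.20 log units higher from compound 3 to compound 4 (within the scatter), a small upward move not beyond the scatter. For compound 4 the estimated value is 2.2, with an expected range of 1.8 to 2.6.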

Compound 4, distribution coefficient: 2.6
For compound 4 the middle estimate is 0.40 log units below the measured one; measured number inside the range.
By their numbers in this assay, from the lowest: compound 3; then compounds 2 and 4 (each within the scatter of the next).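

Replacing oxolan-3-yl with methyl on this saturated chain carbon gives the first measured loss of the ring, and the change is a real one in this assay: a number 0.60 log units higher from compound 3 to compound 4 (beyond the scatter). Measured against the other ring-bearing group, the smaller group gives only a number 0.20 log units higher from compound 2 to compound 4 (within the scatter), so losing a ring at this position does not produce a shift beyond the scatter in every comparison, and the outcome depends on which ring-bearing compound serves as the reference. No supporting measurement accounts for either step.

On these data alone, whether the read-out follows the size of the group at this carbon remains open, as one acyclic group cannot define a trend. An ethyl group, a longer chain or an amine at this carbon would test how far the methyl result extends.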